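This account rests on a few compounds, and the source may have more. Where it says the series, first, only, none or still open, it means among the compounds named here.

Compound 1 `O=C(NCc1ccc(NC(=O)c2cccc(F)c2N2CCCC2)cc1)OCc1cccnc1`: in a functional assay on MGC-803 cells (Homo sapiens) for inhibition, read by MTT assay, with a stated time of 72 h (on this read-out lower numbers stand for stronger inhibition and higher numbers for weaker inhibition), compound 1 gives only a limit, > 100000 nM.
Compound 2 `O=C(NCc1ccc(NC(=O)c2ccc(F)cc2N2CCCC2)cc1)OCc1cccnc1`: in this assay compound 2 gives 52100 nM.
Compound 3 `Cc1cccc(C(=O)Nc2ccc(CNC(=O)OCc3cccnc3)cc2)c1N1CCCC1`: in this assay compound 3 gives only a limit, > 100000 nM.

Compound 2 is the only one of the three with a number, while compound 1 and compound 3 each end at a limit of the assay. The difference between the cores of compound 1 and compound 2 is not broken down here. Compound 3 differs from compound 1 by methyl in place of fluoro on an aromatic carbon, and the step that the two limits leave unreadable from compound 1 to compound 3 cannot be read because of the limit of > 100000 nM in this assay, at which 2 of the 3 values shown sit.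

Compound 4 `Cc1ccc(C(=O)Nc2ccc(CNC(=O)OCc3cccnc3)cc2)c(N2CCCC2)c1` is not yet measured. It differs from compound 2 by methyl in place of fluoro on an aromatic carbon. This is the same kind of change as that from compound 1 to compound 3, not the same: in compound 3 the methyl sits ortho to a pyrrolidin-1-yl group and meta to a large group, in compound 4 meta to a pyrrolidin-1-yl group and para to a large group. The measured pair gives no readable size, so the expectation for compound 4 rests only on compound 2 and its value 52100 nM. Compound 4 is expected to move by a 1.3-fold higher number from compound 2 to compound 4 (0.13 log units; within the scatter) in this assay. Compound 4 is therefore estimated at 70000 nM in this assay, with a likely range from 25000 nM to 200000 nM.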

Compound 4, half-maximal inhibitory concentration: > 100000 nM
Compound 4: no number, only a limit (the forecaster's own chance of this, stated with the estimate: 35%); at least 1.4-fold (0.15 log units) between middle value and limit.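

In this assay, on these data alone, methyl in place of fluoro on the core of compound 2 gives an at least 1.9-fold higher number from compound 2 to compound 4 (0.28 log units; that floor lies within the scatter), so this step has only a floor and its true size stays unknown. Compound 3 and compound 4, the two methyl compounds, both end at a limit, which shows that the change yields no measured number on either core, but the step on the core of compound 1 cannot be read. The series therefore gives no two sizes to compare, and it does not show that the change carries over from one core to the other with the same effect: the limit of > 100000 nM in this assay, at which 3 of the 4 values shown sit.

The compounds shown leave open whether an amine or a carboxylic acid in place of fluoro, on the same aromatic carbon of the core of compound 2, would give a lower number than compound 2, which gives 52100 nM. Also open, as far as these compounds go, is how far past the limit compound 1, compound 3 and compound 4 lie.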